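From 4-hydroxyphenyl to 3,4-dihydroxyphenyl on compound 2

The source may hold more compounds than are shown below. What is called first, only, known or untested is meant among the compounds shown, and "the series" means these compounds.

In a functional assay on PC-3 cells (Homo sapiens) for inhibition, read by sulforhodamine B assay, with a stated time of 72 h (a lower number here means a stronger inhibitor, a higher number a weaker inhibitor), compound 1 `C[C@H](OC(=O)/C=C\c1ccc(O)cc1)[C@@H]1CC[C@H]([C@H](O)[C@H]2CC=CC(=O)O2)O1` gives 8800 nM. Compound 2 `C[C@H](OC(=O)/C=C/c1ccc(O)cc1)[C@@H]1CC[C@H]([C@H](O)[C@H]2CC=CC(=O)O2)O1` gives > 10000 nM, which is a limit of the assay. Going by the values given here, the one measured step, an at least 1.1-fold higher number from compound 1 to compound 2 (0.05 log units; that floor lies within the scatter), concerns only the fact that compounds 1 and 2 differ only in the configuration as drawn and does not exceed the scatter. Compound 3 `C[C@H](OC(=O)/C=C/c1ccc(O)c(O)c1)[C@@H]1CC[C@H]([C@H](O)[C@H]2CC=CC(=O)O2)O1` differs from compound 2 by hydroxy in place of hydrogen on an aromatic carbon. Among the compounds with values here, no measured step covers such a change, so no direction can be drawn from the data. The expected step that the limit leaves unreadable from compound 2 to compound 3 stays within the scatter. Compound 3 is estimated at 11000 nM, with an expected range of 4000 nM to 25000 nM.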

Compound 3, half-maximal inhibitory concentration: > 10000 nM
Compound 3: a limit, no number; the forecaster's own chance of this, stated with the estimate: 55%; the middle value lies beyond the limit too.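

No step can be read between compound 2 and compound 3, as both results in this assay are limits, not numbers. As far as these compounds go, whether going from 4-hydroxyphenyl to 3,4-dihydroxyphenyl changes the inhibition at all remains open.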